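Trifluoromethylphenyl for chlorofluorophenyl: a repeated exchange

This account rests on a few compounds, and the source may have more. Where it says the series, first, only, none or still open, it means among the compounds named here.

Compound 1 `COc1cc2ncnc(Nc3ccc(F)c(Cl)c3)c2cc1OCCCSc1nc2ccccc2o1` and compound 2 `COc1cc2ncnc(Nc3cccc(C(F)(F)F)c3)c2cc1OCCCSc1nc2ccccc2o1` share a core bearing the (1,3-benzoxazol-2-yl)sulfanyl group; compound 3 `CCCCc1nc(Cl)c(CO)n1CCCOc1cc2c(Nc3ccc(F)c(Cl)c3)ncnc2cc1OC` and compound 4 `CCCCc1nc(Cl)c(CO)n1CCCOc1cc2c(Nc3cccc(C(F)(F)F)c3)ncnc2cc1OC` bear instead the 2-butyl-4-chloro-5-(hydroxymethyl)-1H-imidazol-1-yl group, the difference between the two cores being (2-butyl-4-chloro-5-(hydroxymethyl)-1H-imidazol-1-yl in place of (1,3-benzoxazol-2-yl)sulfanyl on a saturated chain carbon, three bonds along the chain from an oxygen on an aromatic ring). In a functional assay on MCF7 cells (Homo sapiens) for cytotoxicity, read by MTT assay, with a stated time of 24 h (a higher number here means a weaker inhibitor, a lower number a stronger inhibitor), compound 1 gives 4050 nM, compound 2 gives 4030 nM, and compound 3 gives 5990 nM. The exchange 3-(trifluoromethyl)phenyl in place of 3-chloro-4-fluorophenyl on a nitrogen on an aromatic ring produced a 1.0-fold lower number from compound 1 to compound 2 (0.00 log units; within the scatter). The core exchange itself gave a 1.5-fold higher number from compound 1 to compound 3 (0.17 log units; within the scatter).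

Compound 4 is not yet measured; it differs from compound 3 by 3-(trifluoromethyl)phenyl in place of 3-chloro-4-fluorophenyl on a nitrogen on an aromatic ring, the same change as between compound 1 and compound 2, at a place described in identical words. In this assay a step like the earlier one is expected, a 1.0-fold lower number from compound 3 to compound 4 (0.01 log units; within the scatter), resting on the flat outcome of a 1.0-fold lower number from compound 1 to compound 2 (0.00 log units; within the scatter) and on compound 3 standing at 5990 nM. Compound 4 is therefore estimated at 5900 nM, with an expected range from 3000 nM to 12000 nM.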

Compound 4, half-maximal inhibitory concentration: 8280 nM
Compound 4: the middle estimate sits 1.4-fold (0.15 log units) below what was measured, within the range that was stated.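

In this assay, 3-(trifluoromethyl)phenyl in place of 3-chloro-4-fluorophenyl on the core bearing the 2-butyl-4-chloro-5-(hydroxymethyl)-1H-imidazol-1-yl group gives a 1.4-fold higher number from compound 3 to compound 4 (0.14 log units; within the scatter), and this step does not differ from the one on the core bearing the (1,3-benzoxazol-2-yl)sulfanyl group: the same change on two cores in this assay, a 1.0-fold lower number (0.00 log units; within the scatter) from compound 1 to compound 2 and a 1.4-fold higher number (0.14 log units; within the scatter) from compound 3 to compound 4, 1.4-fold (0.14 log units) apart, within the scatter of two such steps

The exchange of the end groups on the chain, read with 3-(trifluoromethyl)phenyl in place, gives a 2.1-fold higher number from compound 2 to compound 4 (0.31 log units; beyond the scatter), and although only this step lies beyond the scatter, it does not differ from the step read with 3-chloro-4-fluorophenyl in place: the same change on two cores in this assay, a 1.5-fold higher number (0.17 log units; within the scatter) from compound 1 to compound 3 and a 2.1-fold higher number (0.31 log units; beyond the scatter) from compound 2 to compound 4, 1.4-fold (0.14 log units) apart, within the scatter of two such steps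

Both changes therefore carry across this pair of cores without a detectable dependence on the other group, but this rests on four compounds in one assay and on small steps, so it does not show that a larger step would carry over or that the same would hold on a third core.

Open, from the compounds shown here alone, is whether this agreement extends to a nitrile or an amine on the phenyl ring. Also open, going by these compounds, is how a longer chain, or a carboxylic acid at its end, would behave.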